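A methyl added to a compound that shows no activity

This account rests on a few compounds, and the source may have more. Where it says the series, first, only, none or still open, it means among the compounds named here.

Of the compounds shown here, two have been measured, compound 1 `Cc1c(CC(O)COCc2ccccc2)[nH]c(=O)[nH]c1=O` and compound 2 `C[Si](C)(C)CCOCn1c(CC(O)COCc2ccccc2)cc(=O)[nH]c1=O`, both of them carrying the same side chain on a shared core. In a functional assay on MIA PaCa-2 cells (Homo sapiens) for antiproliferative activity, read by MTT assay, with a stated time of 72 h (a lower number here means a stronger inhibitor, a higher number a weaker inhibitor), compound 1 gives > 100000 nM, which is a limit of the assay rather than a number. In this assay compound 2 likewise gives > 100000 nM, again a limit of the assay and not a measured value. Among the compounds with values here, compound 2 therefore stands nowhere above or below compound 1; both simply sit at the limit of > 100000 nM in this assay, at which 2 of the 2 values shown sit, so no step between them can be counted.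

Compound 3 `Cc1c(CC(O)COCc2ccccc2)n(COCC[Si](C)(C)C)c(=O)[nH]c1=O` has not yet been measured. It differs from compound 2 by methyl in place of hydrogen on an aromatic carbon, which is methyl in place of hydrogen on an aromatic carbon. Within the data shown here, because compound 2 gives > 100000 nM and compound 1 gives > 100000 nM, no measured step exists from which the size of the change could be read. The expectation is therefore no step beyond the scatter, with compound 3 estimated at 100000 nM, between 30000 nM and 300000 nM. The step from compound 2 to compound 3 is expected to be a number no higher from compound 2 to compound 3 (the limit leaves the size open), with the result most likely reported again as a limit.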

Compound 3, half-maximal inhibitory concentration: > 100000 nM
Compound 3 was reported as a limit; the forecaster's own chance of this, stated with the estimate: 85%; the middle value lies on the limit itself.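

In this assay compound 3 gives > 100000 nM, which is a limit of the assay and not a number. Within the data shown here, no step to compound 3 can be read from compound 1 or compound 2: the limit of > 100000 nM in this assay, at which 3 of the 3 values shown sit. The compounds shown leave open whether the methyl, or the group on the aromatic nitrogen, changes the activity at all.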